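A few compounds are considered here, and "the series" means these few. Any claim that something is new, unique, unknown or untested is made for them only; others in the source may bear on it.

Measured so far in a functional assay on K562 cells (Homo sapiens) for cytotoxicity, read by MTT assay and WST assay, with a stated time of 72 h; a higher number here means a weaker inhibitor, a lower number a stronger inhibitor:
compound 2 `COc1cc2c(Nc3ccc4sc(C(=O)Nc5c(C)cccc5Cl)cc4c3)ncnc2cc1OCCCN1CCCCC1C` — 2150 nM;
compound 3 `CCN(CC)CCCOc1cc2ncnc(Nc3ccc4sc(C(=O)Nc5c(C)cccc5Cl)cc4c3)c2cc1OC` — 3550 nM;
compound 1 `Cc1nc(Nc2ccc3sc(C(=O)Nc4c(C)cccc4Cl)cc3c2)cc(N2CCCCC2)n1` — "not determined" (no result reported).

Compound 3 holds the highest of the two numbers in this assay; compound 2 is nearest, and the change from compound 2 to compound 3 gave a 1.7-fold higher number from compound 2 to compound 3 (0.22 log units; within the scatter). The next step leads to compound 4 `COc1cc2c(Nc3ccc4sc(C(=O)Nc5c(C)cccc5Cl)cc4c3)ncnc2cc1OCCCN1CCCCC1`, the change being (piperidin-1-yl in place of diethylamino on a saturated chain carbon, three bonds along the chain from an oxygen on an aromatic ring). Going by the values given here, the only measured step that bears on it is the one from compound 2 to compound 3, where the amine at the chain end was exchanged and the number moved within the scatter. Compound 4 restores a ring amine there, so no step beyond the scatter is expected in this assay, with a lean back toward compound 2. Compound 4 is estimated at 2700 nM (range 1300 nM to 5500 nM), an expected step of a 1.3-fold lower number from compound 3 to compound 4 (0.12 log units; within the scatter).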

Compound 4, half-maximal inhibitory concentration: 4010 nM
The estimate for compound 4 lay 1.5-fold (0.17 log units) below the measured number, and the stated range covers the measured number.
By their numbers in this assay, from the lowest: compounds 2, 3 and 4 (each within the scatter of the next).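

Piperidin-1-yl in place of diethylamino, on a saturated chain carbon three bonds along the chain from an oxygen on an aromatic ring, gives a 1.1-fold higher number from compound 3 to compound 4 (0.05 log units; within the scatter) in this assay at this chain end. Hydrogen in place of methyl on a saturated ring carbon gives a 1.9-fold higher number from compound 2 to compound 4 (0.27 log units; within the scatter) on the same piperidine ring. Compounds 2, 3 and 4 therefore read alike, and no measured evidence accounts for this here.

Still open, from the compounds shown here alone, is whether a morpholine or piperazine ring at the chain end, or a shorter or longer chain, would give a step beyond the scatter.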